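Swapping the aryl group on the hydrazone carbon

The compounds below may be only part of what the source reports. "The series", "measured", "known", "first", "only" and "open" are said of these compounds alone.

Of the compounds shown here, three sharing one core have been tested in a functional assay on U-87MG ATCC cells (Homo sapiens) for cytotoxicity, read by MTT assay, with a stated time of 72 h; a lower number here means a stronger inhibitor, a higher number a weaker inhibitor. Compound 1 `CN(C)CCn1cnnc1-c1cc(Oc2ccc(NC(=O)N/N=C/c3cccc(Br)c3)cc2F)ccn1` gives 830 nM, the lowest of the three numbers. Compound 2 `CN(C)CCn1cnnc1-c1cc(Oc2ccc(NC(=O)N/N=C/c3ccc(F)cc3Cl)cc2F)ccn1` gives 1210 nM, and the change between them amounts to a 1.5-fold higher number from compound 1 to compound 2 (0.16 log units; within the scatter). Compound 3 `CN(C)CCn1cnnc1-c1cc(Oc2ccc(NC(=O)N/N=C/c3ccc(O)cc3)cc2F)ccn1`, which carries a hydroxyl group on the aryl ring, gives 7750 nM; the step of a 9.3-fold higher number from compound 1 to compound 3 (0.97 log units; beyond the scatter) and the step of a 6.4-fold higher number from compound 2 to compound 3 (0.81 log units; beyond the scatter) both show that this hydroxyphenyl compound is the weaker inhibitor by a modest margin.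

Compound 4 `CN(C)CCn1cnnc1-c1cc(Oc2ccc(NC(=O)N/N=C/c3c(O)ccc4ccccc34)cc2F)ccn1` is not yet measured. Its difference from compound 1 is 2-hydroxynaphthalen-1-yl in place of 3-bromophenyl on a carbon with a double bond to nitrogen. Within the data shown here, the new group brings a hydroxyl, as compound 3 did, but set on a larger two-ring aromatic system, which none of the measured compounds carries. From the compounds shown here alone, the halogen-bearing rings of compound 1 and compound 2 sit close together, so the main guide is the weakening seen with the hydroxyl, a 9.3-fold higher number from compound 1 to compound 3 (0.97 log units; beyond the scatter), tempered by the fact that the extra ring is untested. Compound 4 is therefore expected to come out as a somewhat weaker inhibitor, with an estimated step of a 3.0-fold higher number from compound 1 to compound 4 (0.48 log units; beyond the scatter). Compound 4 is estimated at 2500 nM, with a range from 600 nM to 10000 nM.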

Compound 4, half-maximal inhibitory concentration: 620 nM
Estimate against measurement, compound 4: 4.0-fold (0.61 log units) above; low and high end bracket the measured number.
By their numbers in this assay, from the lowest: compounds 4, 1 and 2 (each within the scatter of the next); then compound 3.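

A hydroxyl on the aryl group does not by itself go with a weak result at this position: in this assay, the change to 2-hydroxynaphthalen-1-yl gives a 1.3-fold lower number from compound 1 to compound 4 (0.13 log units; within the scatter) and a 2.0-fold lower number from compound 2 to compound 4 (0.29 log units; within the scatter), so compound 4 cannot be told apart from either halogen-bearing compound. Among the hydroxyl-bearing compounds, the same position shows a 13-fold lower number from compound 3 to compound 4 (1.10 log units; beyond the scatter), which means that compound 3 is the one that goes against the other three and that this position can hold a larger, two-ring aromatic group with no loss beyond the scatter. No measured evidence is available to explain why these two hydroxyl-bearing groups give such different numbers.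

Compound 3 and compound 4 differ in both the placement of the hydroxyl and the second aromatic ring, so the compounds shown cannot say which of these features matters; naphthalen-1-yl, which has no hydroxyl, and 2-hydroxyphenyl, which has only one ring, would help to separate them. From the compounds shown here alone, it also remains open how this position would respond to an aryl group carrying an amine or a carboxylic acid.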